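The compounds below may be only part of what the source reports. "The series", "measured", "known", "first", "only" and "open" are said of these compounds alone.

Measured so far in a functional assay on K562 cells (Homo sapiens) for inhibition, read by trypan blue exclusion, with a stated time of 72 h; a lower number here means a stronger inhibitor, a higher number a weaker inhibitor:
compound 1 `Cn1c(=O)c(S(=O)(=O)c2ccc(F)cc2F)cc2cnc(Nc3ccc4cc[nH]c4c3)nc21`: 5000 nM
compound 2 `Cn1c(=O)c(S(=O)(=O)c2ccc(F)cc2F)cc2cnc(Nc3ccc4[nH]c(C(=O)O)cc4c3)nc21`: 10000 nM
compound 3 `Cn1c(=O)c(S(=O)(=O)c2ccc(F)cc2F)cc2cnc(Nc3ccc4sccc4c3)nc21`: 500 nM

Compound 3 has the lowest number of the three, set apart from compound 1 by a 10-fold lower number from compound 1 to compound 3 (1.00 log units; beyond the scatter) and from compound 2 by a 20-fold lower number from compound 2 to compound 3 (1.30 log units; beyond the scatter), both gaps beyond the scatter. Compound 4 `Cn1c(=O)c(S(=O)(=O)c2ccc(F)cc2F)cc2cnc(Nc3ccncn3)nc21` is not yet measured. It differs from compound 3 in one place: pyrimidin-4-yl in place of 1-benzothiophen-5-yl on a nitrogen on an aromatic ring. Among the compounds with values here, no measured step brings in a pyrimidin-4-yl, so the evidence is indirect. The steps of a 10-fold lower number from compound 1 to compound 3 (1.00 log units; beyond the scatter) and a 20-fold lower number from compound 2 to compound 3 (1.30 log units; beyond the scatter) show that the group on this nitrogen moves the number strongly, and 1-benzothiophen-5-yl gave the lowest value. Replacing it is therefore expected to raise the number, with the step of a 10-fold higher number from compound 3 to compound 4 (1.00 log units; beyond the scatter) estimated. For compound 4 the estimate in this assay is 5000 nM, ranging from 1000 nM to 25000 nM.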

Compound 4, half-maximal inhibitory concentration: 30000 nM
Beside the measured number, compound 4's estimate is 6.0-fold (0.78 log units) below it, outside the stated range (above it).
By their numbers in this assay, from the lowest: compound 3; then compounds 1 and 2 (each within the scatter of the next); then compound 4.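

In this assay, within the data shown here, the single-ring pyrimidin-4-yl gives the highest number so far, above all three two-ring groups on this nitrogen. The rise is large against 1-benzothiophen-5-yl (a 60-fold higher number from compound 3 to compound 4 (1.78 log units; beyond the scatter)) and modest against 1H-indol-6-yl (a 6.0-fold higher number from compound 1 to compound 4 (0.78 log units; beyond the scatter)) and 2-carboxy-1H-indol-5-yl (a 3.0-fold higher number from compound 2 to compound 4 (0.48 log units; beyond the scatter)). No measurement here explains these changes.

With only one single-ring group shown, ring count and ring nitrogens cannot be told apart. A plain phenyl ring, or a pyrimidin-4-yl carrying a methoxy group, would help separate them.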